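The compounds below may be only part of what the source reports. "The series", "measured", "known", "first", "only" and "open" are said of these compounds alone.

Compound 1 `COc1cc(NCc2ccccc2)cc(OC)c1OC`: > 80000 nM
Compound 2 `COc1cc(NCc2ccc(Cl)cc2)cc(OC)c1OC`: > 80000 nM
Compound 3 `COc1cc(NCc2cccc(O)c2)cc(OC)c1OC`: 71300 nM

Among the compounds with values here, in a functional assay on KYSE-450 cells (Homo sapiens) for inhibition, read by MTT assay, with a stated time of 48 h (a higher number here means a weaker inhibitor, a lower number a stronger inhibitor), compound 3 gives the only number among the three; compound 1 and compound 2 each sit at a limit of the assay rather than a number, (the limit of > 80000 nM in this assay, at which 2 of the 3 values shown sit). Compound 4 `COc1cc(NCc2ccc(C)cc2)cc(OC)c1OC` differs from compound 3 by 4-methylphenyl in place of 3-hydroxyphenyl on a saturated chain carbon bound to a nitrogen on an aromatic ring. Within the data shown here, two measured steps bear on this change: an at least 1.1-fold lower number from compound 2 to compound 3 (0.05 log units; that floor lies within the scatter) and an at least 1.1-fold lower number from compound 1 to compound 3 (0.05 log units; that floor lies within the scatter), both floors lying within the scatter, while a step that the two limits leave unreadable from compound 1 to compound 2 cannot be read. The change now runs in the opposite direction, so the number is expected to move back toward the limit; the expected step is a 1.3-fold higher number from compound 3 to compound 4 (0.10 log units; within the scatter). Compound 4 is therefore estimated at 90000 nM, between 40000 nM and 200000 nM, with a fair chance that this assay again returns only a limit.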

Compound 4, half-maximal inhibitory concentration: > 80000 nM
Compound 4: only a limit was reported (the forecaster's own chance of this, stated with the estimate: 65%); the middle value lies beyond the limit too.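

In this assay compound 4 also stops at a limit, now the third compound to do so: the limit of > 80000 nM in this assay, at which 3 of the 4 values shown sit.

Within the data shown here, replacing 3-hydroxyphenyl with 4-methylphenyl gives an at least 1.1-fold higher number from compound 3 to compound 4 (0.05 log units; that floor lies within the scatter), so this change does not separate the one measured number from the limit. The steps from compound 1 and from compound 2 to compound 4 cannot be read, since both ends are limits.

As far as these compounds go, what remains open is whether any group at this place moves the shared core clear of the limit, such as an amine, a carboxylic acid or a longer chain.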